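The source may report more compounds than this note shows. Statements on the series, on what has been measured and on what is new or still open speak of the compounds shown alone.

Series notes, read-outs in a functional assay for inhibition, with Rattus norvegicus as the target, at pH 7.35; on this read-out higher numbers stand for weaker inhibition and lower numbers for stronger inhibition:

- compound 1 `CCC(NC(=O)C(CC(C)C)NC(=O)OCc1ccccc1)C(=O)C(=O)OC`: 280000 nM
- compound 2 `CCOC(=O)C(=O)C(CC)NC(=O)C(CC(C)C)NC(=O)CCc1ccccc1`: 20000 nM
- compound 3 `CCOC(=O)C(=O)C(CC)NC(=O)C(CC(C)C)NC(=O)C(c1ccccc1)c1ccccc1`: > 100000 nM, a limit of the assay and not a number

Going by the values given here, only two of the three readings are true numbers, and compound 2 has the lower of them. Compound 1 is its nearest neighbour, and the distance between the two lies beyond the scatter. The reading for compound 3 remains a limit: the limit of > 100000 nM in this assay, at which 1 of the 3 values shown sits.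

The next compound to be tested in this assay is compound 4 `CCOC(=O)C(=O)C(CC)NC(=O)C(CC(C)C)NC(=O)OCC(C)C`. It carries isobutoxy in place of phenethyl on a carbonyl carbon whose other neighbours are: amide-type nitrogen. The counted difference is isobutoxy in place of phenethyl on a carbonyl carbon.

Among the compounds with values here, no measured pair isolates this change, so any expectation rests on thin ground. Within the data shown here, compound 2 gives the lowest number so far at 20000 nM, so a replacement seems more likely to raise the number than to lower it. The expected move is therefore towards weaker inhibition, of moderate size and with wide uncertainty. The estimated step is a 2.5-fold higher number from compound 2 to compound 4 (0.40 log units; beyond the scatter). For compound 4 the estimated value is 50000 nM, with an expected range of 12000 nM to 200000 nM.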

Compound 4, half-maximal inhibitory concentration: > 300000 nM
Compound 4: no number, only a limit (the forecaster's own chance of this, stated with the estimate: 30%); middle value at least 6.0-fold (0.77 log units) away from the limit.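

In this assay, going by these compounds alone, the exchange of phenethyl for isobutoxy on a carbonyl carbon whose other neighbours are: amide-type nitrogen is the only single change that can be read, and it gives an at least 15-fold higher number from compound 2 to compound 4 (1.17 log units; beyond the scatter). This shows that the position is not indifferent to what it carries: with phenethyl, compound 2 keeps a true number, whereas the isobutoxy of compound 4 moves the reading out of the measurable range. Compound 4 gives > 300000 nM, which is a limit of the assay and not a number, so the step fixes only a minimum size and the real distance stays unknown: the limit of > 300000 nM in this assay, at which 1 of the 4 values shown sits.

The exchange removes the six-membered aromatic ring, shortens the group and brings in an oxygen all at once, so this one pair cannot say which of these differences matters. A cyclohexylethyl group on the same carbonyl carbon would test the aromatic ring apart from the size of the group, and a phenoxymethyl group would test the added oxygen while keeping the ring.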